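Two limit values and a dichlorophenyl swap

A few compounds are considered here, and "the series" means these few. Any claim that something is new, unique, unknown or untested is made for them only; others in the source may bear on it.

The shared core carries two aromatic rings on double-bonded chain carbons. Compound 1 `COc1cccc(/C=C2\CCC/C(=C\c3ccccc3Cl)C2=O)c1OC` is one such pair. In a functional assay on A549 cells (Homo sapiens) for cytotoxicity, read by MTT assay, with a stated time of 72 h (a lower number here means a stronger inhibitor, a higher number a weaker inhibitor), compound 1 gives only the limit > 20000 nM, which is not a number. Compound 2 `COc1ccccc1/C=C1\CCC/C(=C\c2ccc(OC)c(OC)c2)C1=O` is measured in this assay and likewise gives only the limit > 20000 nM. So compound 2 stands where every value shown stands, on the limit itself; the evidence is simply (the limit of > 20000 nM in this assay, at which 2 of the 2 values shown sit), with no numerical step to learn from.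

Compound 3 `COc1ccc(/C=C2\CCC/C(=C\c3cc(Cl)cc(Cl)c3)C2=O)cc1OC` differs from compound 2 in one place: 3,5-dichlorophenyl in place of 2-methoxyphenyl on a double-bonded chain carbon bound to a double-bonded ring carbon. Among the measured compounds shown here, with no measured step between two compounds that differ in one place, no direction can be read from the data. The expected step that the limit leaves unreadable from compound 2 to compound 3 is none beyond the scatter, and compound 3 is expected to come out near 25000 nM, with a range from 8000 nM to 80000 nM, most likely again as a limit.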

Compound 3, half-maximal inhibitory concentration: 5500 nM
Compound 3: middle estimate off by 4.5-fold (0.66 log units), on the high side; the measured number lies below the stated range.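

In this assay, this place on a double-bonded chain carbon bound to a double-bonded ring carbon now shows that a single change of group can move the result: 3,5-dichlorophenyl in place of 2-methoxyphenyl gives an at least 3.6-fold lower number from compound 2 to compound 3 (0.56 log units; beyond the scatter). Among the compounds shown here, compound 3, at 5500 nM, also gives the first true number in this set, so the shared core can show activity that this assay can measure. The step is a minimum and not an exact size because compound 2 has only a limit: the limit of > 20000 nM in this assay, at which 2 of the 3 values shown sit.

The compounds shown do not separate the effect of bringing in the two chlorines from that of removing the methoxy group. As far as these compounds go, how plain phenyl, or a phenyl carrying an amine or a carboxylic acid, would behave at this place remains open.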